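The source may report more compounds than this note shows. Statements on the series, on what has been measured and on what is new or still open speak of the compounds shown alone.

Measured compounds:
Compound 1, `C=C(C)C(=O)N(Cc1ccc(OC)c(O)c1)c1cc(OC)c(OC)c(OC)c1`, 200 nM
Compound 2, `COc1ccc(CN(C(=O)CCCl)c2cc(OC)c(OC)c(OC)c2)cc1O`, 150 nM

Both were tested in a functional assay on HCT-116 cells (Homo sapiens) for inhibition, read by MTT assay, with a stated time of 48 h; a lower number here means a stronger inhibitor, a higher number a weaker inhibitor. Compound 2 gives the lower of the two numbers, but the step of a 1.3-fold lower number from compound 1 to compound 2 (0.12 log units; within the scatter) shows that the two values sit within the scatter of each other, so no order between compound 1 and compound 2 can be claimed.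

Compound 3, `COc1ccc(CN(C(=O)/C=C/CBr)c2cc(OC)c(OC)c(OC)c2)cc1O`, has not yet been measured in this assay. It differs from compound 2 in one place: 3-bromoprop-1-en-1-yl in place of 2-chloroethyl on a carbonyl carbon. Going by the values given here, the only step that bears on this change is the one at the same position, a 1.3-fold lower number from compound 1 to compound 2 (0.12 log units; within the scatter), where exchanging the group on the carbonyl carbon left the value within the scatter. On that basis a step of similar size is expected for compound 3, that is, a 1.3-fold lower number from compound 2 to compound 3 (0.10 log units; within the scatter), with no clear direction beyond the scatter. Compound 3 is therefore estimated at 120 nM, within a range from 50 nM to 300 nM.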

Compound 3, half-maximal inhibitory concentration: 59 nM
For compound 3 the middle estimate is 2.0-fold (0.31 log units) above the measured one; the measured number falls inside the stated range.
By their numbers in this assay, from the lowest: compound 3; then compounds 2 and 1 (each within the scatter of the next).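

In this assay the group on the carbonyl carbon now makes a difference beyond the scatter: the step to 3-bromoprop-1-en-1-yl from 2-chloroethyl is a 2.5-fold lower number from compound 2 to compound 3 (0.41 log units; beyond the scatter), and the step to the same group from 1-methylethenyl is a 3.4-fold lower number from compound 1 to compound 3 (0.53 log units; beyond the scatter). Both steps are modest, but compound 3 stands apart from compound 1 and compound 2, a separation the exchange between those two earlier compounds did not produce. No measurement shown here explains this gain.

The bromine and the double bond enter together, so the compounds shown leave open which of them carries the step; a 3-chloroprop-1-en-1-yl or a saturated 3-bromopropyl group on the same carbonyl carbon would separate the two. From the compounds shown here alone, how an amine or a carboxylic acid in place of the bromine would compare also remains open.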